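A few compounds are considered here, and "the series" means these few. Any claim that something is new, unique, unknown or untested is made for them only; others in the source may bear on it.

Measured so far:
compound 1 `C=C[C@@](C)(/C=C/c1ccc(OC(C)=O)cc1)CCC=C(C)C`: 60%
compound 2 `C=C[C@@](C)(/C=C/c1ccc(OC)cc1)CCC=C(C)C`: 31%

In a functional assay on PC-3 cells (Homo sapiens) for inhibition, with a stated time of 48 h, tested at 30 uM (on this read-out higher numbers stand for more inhibition of growth at the one concentration tested and lower numbers for less inhibition of growth), compound 2 gives 31%, the lower of the two numbers. The next compound is compound 3 `COc1ccc(/C=C/[C@](C)(/C=C/c2ccc(O)cc2)CCC=C(C)C)cc1`, which carries 2-(4-hydroxyphenyl)ethenyl in place of vinyl on a saturated chain carbon bound to a double-bonded chain carbon and two saturated chain carbons. Among the measured compounds shown here, only one measured step exists, a number 29 percentage points lower from compound 1 to compound 2 (beyond the scatter), and it concerns the group on the aromatic oxygen, not this place. For the measured compounds named here, it bears on the new change only as a guide to size, and no measured compound shows the effect of this replacement. A modest step upward is expected, with the direction poorly supported. The expected step is a number 14 percentage points higher from compound 2 to compound 3 (beyond the scatter). For compound 3 the estimated value is 45%, with an expected range of 25% to 68%.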

Compound 3, percent growth inhibition at one concentration: 50%
Beside the measured number, compound 3's estimate is 5 percentage points below it; low and high end bracket the measured number.
By their numbers in this assay, from the lowest: compound 2; then compounds 3 and 1 (each within the scatter of the next).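

At the saturated chain carbon bound to a double-bonded chain carbon and two saturated chain carbons, vinyl can be exchanged for a much larger group without loss of growth inhibition: in this assay, 2-(4-hydroxyphenyl)ethenyl in its place gives a number 19 percentage points higher from compound 2 to compound 3 (beyond the scatter). Among the compounds shown here, this is the first measured change at this position, and the entering group brings an aromatic ring and a hydrogen-bond donor together, so the step belongs to the whole group and not to either part alone. No measurement available here explains the rise.

The compounds shown do not separate the hydroxyl from the aromatic ring; a plain 2-phenylethenyl group at this place would address that. Also open, going by these compounds, is how an amine or a carboxylic acid in place of the hydroxyl would read out in this assay.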